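A few compounds are considered here, and "the series" means these few. Any claim that something is new, unique, unknown or untested is made for them only; others in the source may bear on it.

Compound 1 `CCCCCCOC(=O)CCC(=O)N1CCN(CCCOc2cc3c(Nc4ccc(F)c(Cl)c4)ncnc3cc2OC)CC1`: 85.1% in a functional assay on A549 cells (Homo sapiens) for cytotoxicity, read by MTT assay, with a stated time of 24 h, tested at 20 uM; a higher number here means a weaker effect of the compound at the concentration tested, a lower number a stronger effect
Compound 2 `CCCCCCCCCCCCCCOC(=O)CCC(=O)N1CCN(CCCOc2cc3c(Nc4ccc(F)c(Cl)c4)ncnc3cc2OC)CC1`: 92.3%

Compound 2 stands highest of the two numbers in this assay, though its step of a number 7.2 percentage points higher from compound 1 to compound 2 (within the scatter) is within the scatter. Compound 3 `CCCCCCCCCCCCCCCOC(=O)CCC(=O)N1CCN(CCCOc2cc3c(Nc4ccc(F)c(Cl)c4)ncnc3cc2OC)CC1` differs from compound 2 by methyl in place of hydrogen on a saturated chain carbon, ten or more bonds along the chain from an oxygen next to a carbonyl group; the change extends the same chain that the earlier step lengthened. Among the measured compounds shown here, only that step bears on the question, and it was within the scatter. Compound 3 is therefore expected to change little, with a number 0.2 percentage points higher from compound 2 to compound 3 (within the scatter) estimated, giving compound 3 an expected value of 92.5%, likely between 82% and 101%.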

Compound 3, a percentage reported as activity, at one concentration (the size of the read-out at that concentration, not a potency): 91.2%
Compound 3: middle estimate off by 1.3 percentage points, on the high side; the range from low to high includes it.
By their numbers in this assay, from the lowest: compounds 1, 3 and 2 (each within the scatter of the next).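

In this assay, methyl in place of hydrogen on a saturated chain carbon, ten or more bonds along the chain from an oxygen next to a carbonyl group, gives a number 1.1 percentage points lower from compound 2 to compound 3 (within the scatter), and nonyl in place of hydrogen gives a number 6.1 percentage points higher from compound 1 to compound 3 (within the scatter). The three chains shown therefore cannot be told apart in this read-out at this concentration. Nothing available accounts for this result. Going by these compounds, it remains open whether a shorter chain, or a chain ending in an amine or a carboxylic acid, would give a different read-out.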